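The source may report more compounds than this note shows. Statements on the series, on what has been measured and on what is new or still open speak of the compounds shown alone.

Of the compounds shown here, three sharing one core have been measured in a functional assay (strain AB) with Danio rerio as the target, read by microscopy, with a stated time of 1 h; a higher number here means that more compound is needed for the effect, a lower number that less compound is needed. Compound 1 `NC(=O)c1c(NC(=O)Nc2ccc(Cl)cc2)sc2c1CCN(C1CCOCC1)C2` gives 2830 nM, compound 3 `CCN1CCc2c(sc(NC(=S)Nc3ccc(Cl)cc3)c2C(N)=O)C1` gives 6570 nM, and compound 2 `CC(C)(C)C[N+]1(C)CCc2c(sc(NC(=O)Nc3ccc(Cl)cc3)c2C(N)=O)C1` gives 290 nM, the lowest number of the three, with both other compounds standing higher by margins beyond the scatter. Compound 4 `CC(C)C[N+]1(C)CCc2c(sc(NC(=O)Nc3ccc(Cl)cc3)c2C(N)=O)C1` has not yet been measured. It differs from compound 2 by one change: hydrogen in place of methyl on a saturated chain carbon bound to three saturated chain carbons. Among the measured compounds shown here, with no measured pair showing this change, the expectation rests on the size of the group removed, which is small, so the step is expected to be modest, likely a slight rise in the number, though possibly within the scatter a 1.4-fold higher number from compound 2 to compound 4 (0.16 log units; within the scatter). Compound 4 is therefore expected to give 420 nM in this assay, in a range from 150 nM to 1200 nM.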

Compound 4, half-maximal effective concentration: 380 nM
For compound 4 the middle estimate is 1.1-fold (0.04 log units) above the measured one; the range from low to high includes it.
By their numbers in this assay, from the lowest: compounds 2 and 4 (each within the scatter of the next); then compound 1; then compound 3.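

In this assay, the change from neopentyl to isobutyl, hydrogen in place of methyl on a saturated chain carbon bound to three saturated chain carbons, gives a 1.3-fold higher number from compound 2 to compound 4 (0.12 log units; within the scatter). Among the compounds shown here, this is the first step that can be read at this position, and it shows that this one methyl can go without a change beyond the scatter. Nothing available accounts for this result.

On these data alone, what a longer chain, a hydroxyl or an amine on this carbon would give remains open.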